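A few compounds are considered here, and "the series" means these few. Any claim that something is new, unique, unknown or untested is made for them only; others in the source may bear on it.

Compound 1 `Nc1ccccc1NC(=O)c1ccc(CSC(=S)N2CCN(c3ccncc3)CC2)cc1`: 87.1%
Compound 2 `Nc1ccccc1NC(=O)c1ccc(CSC(=S)N(Cc2ccccc2)Cc2ccccc2)cc1`: 30.7%

Both numbers come from a functional assay on MGC-803 cells (Homo sapiens) for antiproliferative activity, read by CCK-8 assay, with a stated time of 72 h, tested at 8 uM; a higher number here means a stronger effect of the compound at the concentration tested, a lower number a weaker effect. In this assay compound 1 gives 87.1%, the higher of the two values; the nearest number belongs to compound 2, which gives 30.7%, a gap that lies beyond the usual scatter. Going by the values given here, no pair of compounds differing in only one place has been measured, so no single-step size is known; the two values show only that the group on the thiocarbamoyl nitrogen can move the read-out a long way.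

Compound 3 `N#Cc1ccc(N2CCN(C(=S)SCc3ccc(C(=O)Nc4ccccc4N)cc3)CC2)cc1` has not yet been measured. It differs from compound 1 in one place: 4-cyanophenyl in place of pyridin-4-yl on an amine nitrogen in a ring. An aromatic ring remains on the ring nitrogen, so a small step is expected, downward if anything, and possibly not beyond the scatter. The step of a number 11.1 percentage points lower from compound 1 to compound 3 (beyond the scatter) is the expected size. Compound 3 is therefore expected to give about 76% in this assay, with a range from 52% to 92%.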

Compound 3, a percentage reported as inhibition, at one concentration (the size of the read-out at that concentration, not a potency): 37.6%
Compound 3: the middle estimate sits 38.4 percentage points above what was measured; measured number below the stated range.
By their numbers in this assay, from the lowest: compounds 2 and 3 (each within the scatter of the next); then compound 1.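

In this assay, going by these compounds alone, this position gives the first single-step measurement: 4-cyanophenyl in place of pyridin-4-yl on an amine nitrogen in a ring gives a number 49.5 percentage points lower from compound 1 to compound 3 (beyond the scatter) and counts as a large step. An aromatic ring stays on that nitrogen in both compounds, and the two groups have equal counts of hydrogen-bond donors and acceptors and no net charge, so neither the presence of an aromatic ring there nor these counts keep the read-out high. No measured property of the compounds bears on this step.

From the compounds shown here alone, how phenyl or pyridin-3-yl on the same nitrogen would read stays open, and with it whether the step follows the loss of the ring nitrogen of pyridin-4-yl or the arrival of the nitrile. Going by these compounds, the read-out also comes from a single concentration, so how this step would appear as a difference in potency remains open.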